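Compound 3 to compound 4: octylsulfanyl to pentyloxy

The compounds below may be only part of what the source reports. "The series", "measured", "known", "first", "only" and "open" are said of these compounds alone.

In an ADME assay on BCBL1 cells (Homo sapiens) for cytotoxicity, with a stated time of 7 days (a lower number here means that less compound is tolerated, a higher number that more compound is tolerated), each entry is a limit:
compound 1 `CN(C)c1nc(N)nc2c1ncn2/C=C1/CC1(CO)CO` gives > 20000 nM
compound 2 `CCCNc1nc(N)nc2c1ncn2/C=C1/CC1(CO)CO` gives > 20000 nM
compound 3 `CCCCCCCCSc1nc(N)nc2c1ncn2/C=C1/CC1(CO)CO` gives > 20000 nM

Compound 3 stands at > 20000 nM as a limit only. For the measured compounds named here, the series so far shows the limit of > 20000 nM in this assay, at which 3 of the 3 values shown sit, and nothing more. Compound 4 `CCCCCOc1nc(N)nc2c1ncn2/C=C1/CC1(CO)CO` follows, with pentyloxy in place of octylsulfanyl on an aromatic carbon as the counted difference: pentyloxy in place of octylsulfanyl on an aromatic carbon. The measured steps bearing on it are a step that the two limits leave unreadable from compound 1 to compound 3 and a step that the two limits leave unreadable from compound 2 to compound 3 and also a step that the two limits leave unreadable from compound 1 to compound 2 and none has a size. With compound 3 at > 20000 nM as a limit, no step beyond the scatter is expected in this assay and another limit is likely. The expected change is a number no higher from compound 3 to compound 4 (the limit leaves the size open) as an estimate only. For compound 4 the estimated value is 20000 nM with an expected range from 8000 nM to 40000 nM in this reading.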

Compound 4, half-maximal cytotoxic concentration: > 20000 nM
Compound 4: a limit, no number (the forecaster's own chance of this, stated with the estimate: 75%); the middle value lies on the limit itself.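

In this assay compound 4 gives > 20000 nM, which is a limit. The steps to compound 4 from compound 1, compound 2 and compound 3 cannot be read. The compounds shown leave open whether these groups differ at all in this assay: the limit of > 20000 nM in this assay, at which 4 of the 4 values shown sit.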